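Benzimidazole-linked methoxyphenols: bromo to hydroxy at the central carbon

The source may report more compounds than this note shows. Statements on the series, on what has been measured and on what is new or still open speak of the compounds shown alone.

Working notes on a small set of analogues that share one core, each tested in an assay for inhibition of Alpha amylase (Homo sapiens), with a stated time of 10 min; on this read-out lower numbers stand for stronger inhibition and higher numbers for weaker inhibition. Compound 1 `COc1cc(-c2nc3cc(F)ccc3[nH]2)cc(OC)c1O` gives 2490 nM. Compound 2 `COc1cc(-c2nc3cc(Cl)ccc3[nH]2)cc(I)c1O` gives 1610 nM. Compound 3 `COc1cc(-c2nc3cc(Cl)ccc3[nH]2)cc(OC)c1Br` gives 1620 nM; among the three numbers this is the second highest, the nearest being compound 2, with a gap that lies within the scatter, and the furthest compound 1, also within the scatter. On these numbers nothing separates the three compounds beyond repeat variation.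

Compound 4 `COc1cc(-c2nc3cc(Cl)ccc3[nH]2)cc(OC)c1O` has not been measured. It differs from compound 3 in one place: hydroxy in place of bromo on an aromatic carbon. Compound 1 carries the same hydroxy group on the same carbon with a different halogen on the core and gives 2490 nM, which sits within the scatter of compound 3. Within the data shown here, no pair of measured compounds isolates this change directly. The step from compound 3 to compound 4 in this assay is therefore expected to be small, a 1.2-fold higher number from compound 3 to compound 4 (0.09 log units; within the scatter), and not beyond the scatter in either direction. For compound 4 the estimate is 2000 nM, with a range from 800 nM to 5000 nM.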

Compound 4, half-maximal inhibitory concentration: 2520 nM
The estimate for compound 4 lay 1.3-fold (0.10 log units) below the measured number, and the stated range covers the measured number.
By their numbers in this assay, from the lowest: compounds 2, 3, 1 and 4 (each within the scatter of the next).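

In this assay, among these compounds, the first pair that isolates this change gives a 1.6-fold higher number from compound 3 to compound 4 (0.19 log units; within the scatter) and so places hydroxy in place of bromo, on the aromatic carbon ortho to two methoxy groups and para to a large group, within repeat variation. Among the compounds shown here, two further single changes stay within the scatter as well: methoxy in place of iodo (a 1.6-fold higher number from compound 2 to compound 4 (0.19 log units; within the scatter)) and chloro in place of fluoro (a 1.0-fold higher number from compound 1 to compound 4 (0.01 log units; within the scatter)), the latter being the first isolated reading of the halogen on the core. Nothing beyond these numbers is available to account for them.

Open, on these data alone, is whether an amine or a carboxylic acid on this carbon would take the number beyond the scatter in either direction. The same question stands for a longer chain in place of a methoxy group.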